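Hydrazone series: fluoro and hydroxyl changes on the aryl ring

The compounds below may be only part of what the source reports. "The series", "measured", "known", "first", "only" and "open" are said of these compounds alone.

Compound 1 `Cc1c(C(=O)N/N=C\c2ccccc2O)oc2cccc(O)c12` gives 8350 nM in a functional assay on PC-3 cells (Homo sapiens) for inhibition; a lower number here means a stronger inhibitor, a higher number a weaker inhibitor. Compound 2 `Cc1c(C(=O)N/N=C\c2c(O)cccc2F)oc2cccc(O)c12` carries a fluoro on the aryl ring and gives 8050 nM in this assay; the step of a 1.0-fold lower number from compound 1 to compound 2 (0.02 log units; within the scatter) is within the scatter, so the two numbers cannot be told apart and compound 2 stands at the same level as compound 1.

Compound 3 `Cc1c(C(=O)N/N=C\c2ccc(O)cc2)oc2cccc(O)c12` differs from compound 2 in one place: 4-hydroxyphenyl in place of 2-fluoro-6-hydroxyphenyl on a carbon with a double bond to nitrogen. Going by the values given here, the only measured step, a 1.0-fold lower number from compound 1 to compound 2 (0.02 log units; within the scatter), concerns a fluoro in place of hydrogen and does not touch the position of the hydroxyl on this ring; it was within the scatter. Among the compounds with values here, no measured pair shows what shifting the hydroxyl does. Taking the two numbers on hand as the only guide, no step beyond the scatter is expected in this assay in either direction, with a wide uncertainty because the change itself is untested. Compound 3 is therefore estimated at 8500 nM, range 3000 nM to 25000 nM, which means an expected step of a 1.1-fold higher number from compound 2 to compound 3 (0.02 log units; within the scatter).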

Compound 3, half-maximal inhibitory concentration: 21700 nM
Estimate against measurement, compound 3: 2.6-fold (0.41 log units) below; low and high end bracket the measured number.
By their numbers in this assay, from the lowest: compounds 2 and 1 (each within the scatter of the next); then compound 3.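

In this assay, going by these compounds alone, the aryl group on the carbon with a double bond to nitrogen is the first place where a change goes beyond the scatter: 4-hydroxyphenyl in place of 2-hydroxyphenyl gives a 2.6-fold higher number from compound 1 to compound 3 (0.41 log units; beyond the scatter) for this swap, and 4-hydroxyphenyl in place of 2-fluoro-6-hydroxyphenyl gives a 2.7-fold higher number from compound 2 to compound 3 (0.43 log units; beyond the scatter) for that one. The fluoro change alone did not separate compound 1 and compound 2, yet both aryl swaps leading to compound 3 raise the number by a modest step, which makes compound 3 the weakest inhibitor of the three. Nothing at hand gives a reason for this shift.

The compounds shown leave open whether the higher number goes with the 4-hydroxyphenyl group itself or with the loss of the 2-hydroxyphenyl arrangement, as the two changes come together in each pair. Going by these compounds, a plain phenyl, a 4-methoxyphenyl or a 4-aminophenyl on the same carbon would bear on that question, and whether any aryl group here can give a number lower than those of compound 1 and compound 2 also remains open.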